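A few compounds are considered here, and "the series" means these few. Any claim that something is new, unique, unknown or untested is made for them only; others in the source may bear on it.

For the measured compounds named here, in a functional assay on HCT-116 cells (Homo sapiens) for inhibition, read by MTT assay, with a stated time of 48 h (a higher number here means a weaker inhibitor, a lower number a stronger inhibitor), two compounds sharing one core have numbers so far. Compound 1 `COc1cc(-c2nccn3cc(-c4ccc(Cl)cc4)nc23)cc(OC)c1OC` gives 351 nM and holds the lower of the two, which makes it the stronger inhibitor of the pair. Compound 2 `COc1cc(-c2nccn3cc(-c4ccc(O)cc4)nc23)cc(OC)c1OC` gives 901 nM as the only other reference. Compound 3 `COc1cc(-c2nccn3cc(-c4ccc(C)cc4)nc23)cc(OC)c1OC` has not yet been measured. Its structure departs from compound 1 by methyl in place of chloro on an aromatic carbon (methyl in place of chloro on an aromatic carbon, para to a large group). Going by the values given here, only one measured step bears on this site: hydroxy in place of chloro on an aromatic carbon gave a 2.6-fold higher number from compound 1 to compound 2 (0.41 log units; beyond the scatter) as a modest change. That step shows that the site responds to a swap of group, but it says nothing directly about methyl. Compound 2 therefore offers only a rough guide to the likely size, and no step beyond the scatter is expected in this assay for this swap. The estimated change is a 1.3-fold higher number from compound 1 to compound 3 (0.11 log units; within the scatter) and would leave little to separate the two compounds. For compound 3 the expected value is 450 nM with an estimated range from 200 nM to 1000 nM in this read-out.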

Compound 3, half-maximal inhibitory concentration: 74 nM
Beside the measured number, compound 3's estimate is 6.1-fold (0.78 log units) above it; measured number outside the range, below it.
By their numbers in this assay, from the lowest: compound 3; then compound 1; then compound 2.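

In this assay the site on the six-membered aromatic ring of carbon only, para to a large group, turns out to move in both directions: the earlier pair had shown only a rise in the number, whereas methyl in place of chloro gives a 4.7-fold lower number from compound 1 to compound 3 (0.68 log units; beyond the scatter) and so shows that chloro is not the best of the groups seen here. Methyl in place of hydroxy gives a 12-fold lower number from compound 2 to compound 3 (1.09 log units; beyond the scatter), a large step, so the three groups at this one site span a much wider spread than compound 1 and compound 2 alone had shown. Chloro and methyl read the same in the computed comparison, each with one heavy atom, no ring and no hydrogen-bond donors or acceptors, so those counts do not separate them, and nothing available here gives a reason for the gap.

Going by these compounds, it remains open whether the gain belongs to methyl alone or extends to a longer chain such as ethyl, or to methoxy, an amine or a carboxylic acid at the same place. On these data alone, it is also open whether this order of methyl, chloro and hydroxy holds on any other core or in any other cell line.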